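The source may hold more compounds than are shown below. What is called first, only, known or untested is meant among the compounds shown, and "the series" means these compounds.

Compound 1 `N/C(=N\NC(=S)N1CCOCC1)c1ccccn1`: 15%
Compound 2 `Cc1cccc(/C(N)=N/NC(=S)N2CCSCC2)n1`: 73.1%
Compound 3 `N/C(=N\NC(=S)N1CCSCC1)c1ccccn1`: 86%

These numbers come from a functional assay on A-375 cells (Homo sapiens) for cytotoxicity, read by MTT assay, with a stated time of 72 h, tested at 30 uM; a higher number here means more inhibition of growth at the concentration tested, a lower number less inhibition of growth. Compound 3 stands highest of the three: the nearer step, a number 12.9 percentage points higher from compound 2 to compound 3 (beyond the scatter), is modest, while the farther one, a number 71 percentage points higher from compound 1 to compound 3 (beyond the scatter), is large. Compound 4 `N/C(=N\NC(=S)N1CCCCC1)c1ccccn1` differs from compound 3 by piperidin-1-yl in place of thiomorpholin-4-yl on a thiocarbonyl carbon. Among the compounds with values here, no measured step exchanges this ring for one holding only a nitrogen, so none bears on it directly; the large step of a number 71 percentage points higher from compound 1 to compound 3 (beyond the scatter) shows only that changing the second hetero atom of this ring shifted the number strongly. A shift beyond the scatter is therefore expected for compound 4, most likely downward, as a number 31 percentage points lower from compound 3 to compound 4 (beyond the scatter), with wide uncertainty. The estimate for compound 4 is 55%, from 15% to 90%.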

Compound 4, percent growth inhibition at one concentration: 87%
The estimate for compound 4 lay 32 percentage points below the measured number; low and high end bracket the measured number.
By their numbers in this assay, from the lowest: compound 1; then compound 2; then compounds 3 and 4 (each within the scatter of the next).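

In this assay, the step of a number 1 percentage points higher from compound 3 to compound 4 (within the scatter) shows that the ring sulfur is not required at this position, since piperidin-1-yl, with carbon in its place, serves as well as thiomorpholin-4-yl. The step of a number 72 percentage points higher from compound 1 to compound 4 (beyond the scatter) is as large as the one seen with thiomorpholin-4-yl, so among these three rings only morpholin-4-yl goes with a low number. Nothing available explains why the ring oxygen stands apart. From the compounds shown here alone, whether a piperazin-1-yl ring or an open-chain group such as diethylamino would hold the number on the thiocarbonyl carbon remains open.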